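This account rests on a few compounds, and the source may have more. Where it says the series, first, only, none or still open, it means among the compounds named here.

In an ADME assay on liver (Homo sapiens) for metabolic stability, read by LC-MS, using S9 fraction, tested at 2 uM (on this read-out higher numbers stand for a longer-lived compound and lower numbers for a shorter-lived compound), three compounds have been measured:

- compound 1 `CCc1ccc(NC(=O)COc2cc(C)nc3ccc(OC)cc23)cc1` gives 0.213 h
- compound 2 `COc1ccc2nc(C)cc(OCC(=O)Nc3ccc4c(c3)CCCC4)c2c1` gives 0.27 h
- compound 3 `COc1ccc2nc(C)cc(OCC(=O)Nc3ccc4c(c3)CCC4)c2c1` gives 0.195 h

All three values lie within the scatter of one another, so compound 1 cannot be separated from either compound 2 or compound 3 on these numbers.

The next compound to be measured is compound 4 `COc1ccc2nc(C)cc(OCC(=O)Nc3ccc(C)cc3)c2c1`, which differs from compound 1 by a single small change: hydrogen in place of methyl on a saturated chain carbon bound to an aromatic carbon. This turns ethyl into methyl and 4-ethylphenyl into 4-methylphenyl.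

Going by the values given here, no measured step makes this exact change. The nearest evidence is a change to the same group, 2,3-dihydro-1H-inden-5-yl in place of 4-ethylphenyl on an amide-type nitrogen, which gave a 1.1-fold lower number from compound 1 to compound 3 (0.04 log units; within the scatter) and stayed within the scatter. Compound 2 also sits close, at 0.27 h with its own group at that nitrogen. A step beyond the scatter in this assay is therefore not expected, and no direction can be favoured.

The step expected is a 1.0-fold higher number from compound 1 to compound 4 (0.01 log units; within the scatter) and it should stay within the scatter. For compound 4 the expected half-life is 0.22 h (estimated range 0.12 h to 0.4 h).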

Compound 4, half-life: 0.423 h
Compound 4: middle estimate off by 1.9-fold (0.28 log units), on the low side, outside the stated range (above it).
By their numbers in this assay, from the lowest: compounds 3, 1, 2 and 4 (each within the scatter of the next, the first and the last beyond it).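

In this assay, cutting the ethyl of 4-ethylphenyl back to the methyl of 4-methylphenyl gives a 2.0-fold higher number from compound 1 to compound 4 (0.30 log units; within the scatter), so this saturated chain carbon bound to an aromatic carbon is now probed directly, yet the step still cannot be told from repeat measurement and does not show that the methyl there matters on its own. Going by these compounds alone, the second step at the same amide-type nitrogen, a 2.2-fold higher number from compound 3 to compound 4 (0.34 log units; beyond the scatter), is modest, but it is the first step here to pass the scatter. Within the data shown here, it shows that the group on this nitrogen can separate two compounds, which the earlier compounds, all within the scatter of one another, could not show.

The compounds shown leave open what a plain phenyl, or a phenyl carrying a chlorine or a carboxylic acid, would give on this nitrogen, and whether a step of this size would hold up with further groups of that kind. Nothing available here bears on the reason for either step.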